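Substituent change on the five-membered ring: compound 4

The source may hold more compounds than are shown below. What is called first, only, known or untested is meant among the compounds shown, and "the series" means these compounds.

Compound 1 `CCCCCCCCc1ccc(OCC(=O)Cn2nnc(C)n2)cc1`, compound 2 `CCCCCCCCc1ccc(OCC(=O)Cn2nnc(SC)n2)cc1` and compound 3 `CCCCCCCCc1ccc(OCC(=O)Cn2nnc(-c3cccs3)n2)cc1` share one core and differ only in the group on an aromatic carbon of the five-membered aromatic ring with 4 nitrogen. In an assay on microsomes from brain for inhibition of Fatty-acid amide hydrolase 1 (Rattus norvegicus), read by fluorescence and HPLC, with a stated time of 60 min (on this read-out higher numbers stand for weaker inhibition and lower numbers for stronger inhibition), compound 1 gives 27 nM, compound 2 gives 31 nM and compound 3 gives 32 nM. Compound 2 stands second highest of the three numbers, with compound 3 nearest and compound 1 furthest, and all three lie within the scatter of one another. The steps of a 1.1-fold higher number from compound 1 to compound 2 (0.06 log units; within the scatter), a 1.2-fold higher number from compound 1 to compound 3 (0.07 log units; within the scatter) and a 1.0-fold higher number from compound 2 to compound 3 (0.01 log units; within the scatter) are each within the scatter.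

Compound 4 `CCCCCCCCc1ccc(OCC(=O)Cn2nnc(-c3cccc(C(=O)O)c3)n2)cc1` has not been measured. Against compound 2 the change is 3-carboxyphenyl in place of methylsulfanyl on an aromatic carbon. The step of a 1.0-fold higher number from compound 2 to compound 3 (0.01 log units; within the scatter) bears most directly, since it too removes methylsulfanyl and puts an aromatic ring at that carbon; the step of a 1.2-fold higher number from compound 1 to compound 3 (0.07 log units; within the scatter) shows the same for thiophen-2-yl against methyl. Within the data shown here, no measured step covers the carboxy part of 3-carboxyphenyl, so that part is untested here. In this assay compound 4 is therefore expected near 45 nM, with a range from 14 nM to 150 nM. The expected step is a 1.5-fold higher number from compound 2 to compound 4 (0.16 log units; within the scatter), most likely within the scatter or only modestly beyond it.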

Compound 4, half-maximal inhibitory concentration: 36 nM
Compound 4: the middle estimate sits 1.3-fold (0.10 log units) above what was measured, within the range that was stated.
By their numbers in this assay, from the lowest: compounds 1, 2, 3 and 4 (each within the scatter of the next).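

Compound 4 extends what the position accepts in this assay: on the aromatic carbon between two ring nitrogen atoms, 3-carboxyphenyl, with its 9 heavy atoms and 1 hydrogen-bond donor, replaces methylsulfanyl without leaving the scatter (a 1.2-fold higher number from compound 2 to compound 4 (0.06 log units; within the scatter)). Among these compounds, its steps against the other two groups also stay within the scatter (a 1.1-fold higher number from compound 3 to compound 4 (0.05 log units; within the scatter); a 1.3-fold higher number from compound 1 to compound 4 (0.12 log units; within the scatter)), so the carboxy part, which no earlier step covered, produces no separation from methyl, methylsulfanyl or thiophen-2-yl on this read-out. No measurement at hand explains why these four groups cannot be told apart.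

With phenyl alone or the methyl ester of the carboxy group absent from the compounds shown, the contribution of the carboxy part cannot be separated from that of the six-membered aromatic ring that carries it. Also open, going by these compounds, is whether the same flat response extends to an aminomethyl group, a carboxylic acid joined through a short alkyl chain, or a longer alkyl chain at this carbon.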